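Cyclopentyl in Place of Methyl on the Amide Nitrogen

The source may hold more compounds than are shown below. What is called first, only, known or untested is meant among the compounds shown, and "the series" means these compounds.

Of the compounds shown here, two have been measured in an assay for inhibition of serine/threonine-protein kinase PLK2 (Homo sapiens), read by FRET and Z'-LYTE, with a stated time of 1 h; on this read-out lower numbers stand for stronger inhibition and higher numbers for weaker inhibition. Compound 1 `CCC1C(=O)N(C)c2cnc(-n3ccc4cc(C(=O)NC)ccc43)nc2N1c1ccn(C)n1` gives 218 nM in this assay, the higher of the two numbers. Within the data shown here, compound 2 `CCNC(=O)c1ccc2c(ccn2-c2ncc3c(n2)N(C2CCCC2)[C@H](CC)C(=O)N3C)c1` gives 4.88 nM in this assay, a number far lower than that of compound 1, well beyond the usual scatter, though the two differ at more than one place and no single step connects them.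

Compound 3 `CCC1C(=O)N(C)c2cnc(-n3ccc4cc(C(=O)NC5CCCC5)ccc43)nc2N1c1ccn(C)n1` has not been measured. It is built from compound 1 by one change: cyclopentyl in place of methyl on an amide-type nitrogen. Among the measured compounds shown here, no measured pair shows this change on its own, so nothing recorded here tells how much the methylcarbamoyl-to-cyclopentylcarbamoyl exchange shifts the number in this assay. The step from compound 1 to compound 3 is therefore expected to be small, likely within the scatter or only a little beyond it, with a slight lean toward a lower number, as a 1.5-fold lower number from compound 1 to compound 3 (0.16 log units; within the scatter).

Compound 3 is expected to give about 150 nM in this assay, most plausibly between 40 nM and 600 nM.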

Compound 3, half-maximal inhibitory concentration: 90.9 nM
Estimate against measurement, compound 3: 1.7-fold (0.22 log units) above; the range from low to high includes it.
By their numbers in this assay, from the lowest: compound 2; then compound 3; then compound 1.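

In this assay the amide-type nitrogen of compound 1 turns out to accept cyclopentyl in place of methyl with no loss, the exchange giving a 2.4-fold lower number from compound 1 to compound 3 (0.38 log units; beyond the scatter) and so a modest move toward stronger inhibition. Among these compounds, this is the first single-place comparison, and it shows that a ring of carbon only can stand on this nitrogen while the rest of the molecule stays unchanged, although the step is a small one beside the wide gap in values that separates compound 2 from compound 1. Nothing measured alongside these numbers bears on why the value falls, so this step records the size of the effect and leaves its origin unexplained.

What the compounds shown leave open is whether the number would keep falling with cyclopropyl, cyclohexyl or phenyl on this nitrogen, or with an open chain such as isopropyl or a longer chain ending in an amine or a carboxylic acid. They also leave open whether the methyl-to-cyclopentyl exchange would move the number by a similar amount on the core of compound 2, since this single pair speaks for the core of compound 1 alone.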